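Fluoro added beside the chloro in a quinazoline boronate pair

The source may report more compounds than this note shows. Statements on the series, on what has been measured and on what is new or still open speak of the compounds shown alone.

Measured compounds and their values:
- Compound 1 `COc1cc2ncnc(Nc3cccc(Cl)c3)c2cc1B1OC(C)(C)C(C)(C)O1`: "not active" (no number reported)
- Compound 2 `CC1(C)OB(c2ccc3ncnc(Nc4cccc(Cl)c4)c3c2)OC1(C)C`: 12%

In an assay on isolated protein for inhibition of vascular endothelial growth factor receptor 1 (Homo sapiens), read by ELISA, with a stated time of 20 min, tested at 1 uM (on this read-out lower numbers stand for less inhibition and higher numbers for more inhibition at the one concentration tested (going by the name of the read-out)), compound 1 is reported as "not active" (no number reported), so no single number stands for it; the read-out records only that it showed no inhibition worth a figure. Compound 2 lacks the methoxy group of compound 1; in this assay compound 2 gives 12%, a value that lies within the usual scatter of a zero reading. Compound 3 `COc1cc2ncnc(Nc3ccc(F)c(Cl)c3)c2cc1B1OC(C)(C)C(C)(C)O1` differs from compound 1 by fluoro in place of hydrogen on an aromatic carbon. Among the compounds with values here, no measured pair shows this same change, so its effect on this assay cannot be read from the data. Because compound 1 gives "not active" (no number reported), the expectation is a step of no size beyond the scatter, in no particular direction. Compound 3 is therefore expected to give about 8% in this assay, with a range from 0% to 30%.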

Compound 3, a percentage reported as inhibition, at one concentration (the size of the read-out at that concentration, not a potency): "not active" (no number reported)
No number was reported for compound 3, and the estimate cannot be compared.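

In this assay, within the data shown here, compound 1 gives "not active" (no number reported) and compound 3 gives "not active" (no number reported) as well, so no step between them can be read. No measurement shown bears on this result. The compounds shown leave open whether fluoro on the 3-chlorophenyl group changes inhibition at all.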